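A few compounds are considered here, and "the series" means these few. Any claim that something is new, unique, unknown or untested is made for them only; others in the source may bear on it.

Working notes on a small set of anilide compounds, read in a functional assay on HCT-116 cells (Homo sapiens) for antiproliferative activity, read by MTT assay, with a stated time of 72 h; a lower number here means a stronger inhibitor, a higher number a weaker inhibitor.

Compound 1 `Cn1c(CNC(=O)c2cccs2)nnc1SCC(=O)Nc1cccc(Cl)c1` sits at the limit of this assay: the value > 100000 nM is a limit, not a measured number. Compound 2 `COc1cc(CNC(C)(C)CO)ccc1OCC(=O)Nc1ccc(C)cc1` likewise returns only a limit, > 100000 nM. Among the measured compounds shown here, compound 3 `Cc1ccc(C(=O)Nc2nc3ccc(NC(=O)CSc4cccc(O)c4)cc3s2)cc1` is the one compound of the set with a measured number, giving 7730 nM in this assay. Where compound 1 stands is therefore plain: the limit of > 100000 nM in this assay, at which 2 of the 3 values shown sit, with no measured step leading to or from it, since no two measured compounds differ in one place.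

The next compound, compound 4 `Cn1c(CNC(=O)c2cccs2)nnc1SCC(=O)Nc1ccc(Cl)cc1`, keeps the core of compound 1 and differs in one place: 4-chlorophenyl in place of 3-chlorophenyl on an amide-type nitrogen. The two have the same atoms, joined differently. For the measured compounds named here, nothing measured in the set bears on the difference between a 3-chlorophenyl and a 4-chlorophenyl on an amide-type nitrogen, so there is no measured step to set the size of this one against.

The expected step from compound 1 to compound 4 in this assay is none beyond the scatter, a number no higher from compound 1 to compound 4 (the limit leaves the size open), and the starting point is itself only a limit. Compound 4 is expected to give about 100000 nM in this assay, between 30000 nM and 300000 nM, and most probably to return only a limit again.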

Compound 4, half-maximal inhibitory concentration: 91400 nM
Compound 4: middle estimate off by 1.1-fold (0.04 log units), on the high side; low and high end bracket the measured number.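

In this assay, 4-chlorophenyl in place of 3-chlorophenyl on an amide-type nitrogen gives an at least 1.0-fold lower number from compound 1 to compound 4 (0.03 log units; that floor lies within the scatter). Compound 1 gives > 100000 nM, which is a limit and not a number, so this step has a floor but no measured size, and the true gap may be larger than that floor. Compound 4 gives 91400 nM, a measured number for the shared core where the 3-chlorophenyl analogue returned none, yet the set as a whole still leans heavily on one boundary of the assay: the limit of > 100000 nM in this assay, at which 2 of the 4 values shown sit.

Still open, as far as these compounds go, is whether any group on this phenyl ring moves the number clearly beyond the scatter, which an unsubstituted phenyl, a 4-methoxyphenyl or a phenyl carrying a carboxylic acid on the same amide-type nitrogen would test. Also open, from the compounds shown here alone, is whether the change from 3-chlorophenyl to 4-chlorophenyl reads the same on a core that gives numbers well inside the range of the assay, such as that of compound 3, which carries neither group.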